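Swapping a cyclobutane for an oxetane on the aminomethyl arm

The compounds below may be only part of what the source reports. "The series", "measured", "known", "first", "only" and "open" are said of these compounds alone.

Compound 1 `Cc1cc(-c2ccnc3[nH]nc(C(F)(F)F)c23)cc(C2(CN)CCC2)c1` and compound 2 `NCC1(c2cccc(-c3ccnc4[nH]nc(C(F)(F)F)c34)c2)CCC1` share one core and differ only in a methyl group on the benzene ring. In an assay on isolated protein for inhibition of protein kinase C delta type (Homo sapiens), read by spectrophotometry, with a stated time of 15 min, in the presence of a further agent that is not named here (on this read-out lower numbers stand for stronger inhibition and higher numbers for weaker inhibition), compound 1 gives 135 nM, the highest of the two numbers recorded, while compound 2 gives 60 nM. Going by the values given here, that change, a 2.3-fold lower number from compound 1 to compound 2 (0.35 log units; beyond the scatter), is the only step measured so far.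

Compound 3 `Cc1cc(-c2ccnc3[nH]nc(C(F)(F)F)c23)cc(C2(CN)COC2)c1` keeps the methyl of compound 1 and instead alters the ring that carries the aminomethyl group: 3-(aminomethyl)oxetan-3-yl in place of 1-(aminomethyl)cyclobutyl on an aromatic carbon. Among the compounds with values here, no measured step touches this part of the molecule, so the step from compound 1 to compound 2 offers no direct guide, and the change itself is small in atom count. The expectation is therefore a step of a 1.0-fold higher number from compound 1 to compound 3 (0.02 log units; within the scatter), within the usual scatter. Compound 3 is estimated at 140 nM in this assay, with a likely range from 50 nM to 400 nM.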

Compound 3, inhibition constant in the protein kinase C delta type assay: 542 nM
Estimate against measurement, compound 3: 3.9-fold (0.59 log units) below; measured number outside the range, above it.
By their numbers in the protein kinase C delta type assay, from the lowest: compound 2; then compound 1; then compound 3.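

In the protein kinase C delta type assay, the ring carrying the aminomethyl group proves sensitive to a small edit: the two groups have the same number of heavy atoms, yet oxygen in the ring in place of carbon gives a 4.0-fold higher number from compound 1 to compound 3 (0.60 log units; beyond the scatter). So this part of the molecule matters for inhibition, which the methyl step alone could not show. The same swap also shifts the read-out of a physicochemical assay for acid dissociation, where compound 1 gives 8.8 and compound 3 gives 7.9. This offers a possible link to the higher number in the protein kinase C delta type assay, though a single pair cannot establish it: the measured acid dissociation constant of compound 1, 8.8, and of compound 3, 7.9, a number 0.90 log units lower (beyond the scatter)

These compounds cannot separate any direct effect of the ring oxygen from that of the shift in acid dissociation. Also open, from the compounds shown here alone, are how a fluorine atom on the cyclobutane would behave and whether the oxetane brings a similar loss on compound 2, which lacks the methyl.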